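Ester chain extension from compound 1 to compound 3

A few compounds are considered here, and "the series" means these few. Any claim that something is new, unique, unknown or untested is made for them only; others in the source may bear on it.

Going by the values given here, compound 1 `COC(=O)c1ccc(COC(COCc2ccc(OC)cc2)Cn2ccnc2)cc1` carries a methoxycarbonyl group on its aryl ring; in a functional assay for inhibition of Thromboxane-A synthase (Homo sapiens) (on this read-out lower numbers stand for stronger inhibition and higher numbers for weaker inhibition), compound 1 gives 1260 nM, the highest of the two numbers measured so far. Compound 2 `CCCOC(=O)c1ccc(COC(COCc2ccc(OC)cc2)Cn2ccnc2)cc1` is its propyl ester analogue, and in this assay compound 2 gives 180 nM. Among the compounds with values here, the single measured step, a 7.0-fold lower number from compound 1 to compound 2 (0.85 log units; beyond the scatter), puts ethyl in place of hydrogen on a saturated chain carbon bound to an oxygen next to a carbonyl group, a change beyond the scatter.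

Compound 3 `CCCCOC(=O)c1ccc(COC(COCc2ccc(OC)cc2)Cn2ccnc2)cc1` is not yet measured. It differs from compound 1 by propyl in place of hydrogen on a saturated chain carbon bound to an oxygen next to a carbonyl group, the same difference read one bond further out as methoxycarbonyl to butoxycarbonyl. Within the data shown here, only the step to compound 2 bears on it, and it was modest. A lowering of about the same size is expected, a 7.4-fold lower number from compound 1 to compound 3 (0.87 log units; beyond the scatter), with no firm ground for a larger one. Compound 3 is therefore estimated at 170 nM, in a range from 55 nM to 550 nM.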

Compound 3, half-maximal inhibitory concentration: 200 nM
For compound 3 the middle estimate is 1.2-fold (0.07 log units) below the measured one; the measured number falls inside the stated range.
By their numbers in this assay, from the lowest: compounds 2 and 3 (each within the scatter of the next); then compound 1.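

Lengthening the ester to butoxycarbonyl keeps the lower number in this assay: the step is a 6.3-fold lower number from compound 1 to compound 3 (0.80 log units; beyond the scatter) and stays beyond the scatter, so the effect seen earlier with one chain length also holds for a second. The further change, methyl in place of hydrogen on a saturated chain carbon, three bonds along the chain from an oxygen next to a carbonyl group, gives a 1.1-fold higher number from compound 2 to compound 3 (0.05 log units; within the scatter) and so separates neither ester from the other, which means that across these two chain lengths the read-out shows no further gain. No evidence is available on what lies behind this levelling.

From the compounds shown here alone, whether a longer chain such as hexyl stays level with these two esters remains open. So does the outcome of replacing the ester with a carboxylic acid or an amide, or of using a branched chain such as isopropyl.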